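Two Chlorines Return on the Urea Aryl of Compound 4

A few compounds are considered here, and "the series" means these few. Any claim that something is new, unique, unknown or untested is made for them only; others in the source may bear on it.

Among the compounds with values here, compound 3 `Cc1cc(NC(=O)Nc2ccccc2Cl)ccc1OCc1nc2ccccc2s1` has the lowest number measured so far in an assay on isolated protein for inhibition of Polyunsaturated fatty acid 5-lipoxygenase (Homo sapiens), read by HPLC, with a stated time of 10 min (a lower number here means a stronger inhibitor, a higher number a weaker inhibitor), where compound 3 gives 680 nM. Compound 1 `Cc1cc(OCc2nc3ccccc3s2)ccc1NC(=O)Nc1ccccc1Cl` gives 830 nM, a gap that lies within the usual scatter, while compound 2 `Cc1cc(NC(=O)Nc2ccc(Cl)c(Cl)c2)ccc1OCc1nc2ccccc2s1` gives 2170 nM. Within the data shown here, the one measured single-point step is a 3.2-fold lower number from compound 2 to compound 3 (0.50 log units; beyond the scatter), a modest gain. Compound 4 `Cc1cc(NC(=O)Nc2cc(Cl)cc(Cl)c2)ccc1OCc1nc2ccccc2s1` differs from compound 3 by 3,5-dichlorophenyl in place of 2-chlorophenyl on an amide-type nitrogen. Among the measured compounds shown here, this change runs the other way from that measured step, a dichlorophenyl again replacing the 2-chlorophenyl, so the expected step is a 2.9-fold higher number from compound 3 to compound 4 (0.47 log units; beyond the scatter), toward weaker inhibition, though this particular dichloro pattern has no direct precedent here. Compound 4 is therefore estimated at 2000 nM, with a likely range from 900 nM to 4500 nM.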

Compound 4, half-maximal inhibitory concentration: 720 nM
For compound 4 the middle estimate is 2.8-fold (0.44 log units) above the measured one; the measured number lies below the stated range.
By their numbers in this assay, from the lowest: compounds 3, 4 and 1 (each within the scatter of the next); then compound 2.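

On this amide-type nitrogen, a second chlorine need not cost activity in this assay: 3,5-dichlorophenyl in place of 2-chlorophenyl gives a 1.1-fold higher number from compound 3 to compound 4 (0.02 log units; within the scatter) and stays level. The two dichlorophenyl groups do not read alike, since a 3.0-fold lower number from compound 2 to compound 4 (0.48 log units; beyond the scatter) shows that chlorine count alone does not set the number. Nothing available here accounts for that difference.

Still open, from the compounds shown here alone, is whether plain phenyl would keep this level. Methoxy, trifluoromethyl or a carboxylic acid on this ring is also untested among the compounds shown.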